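The compounds below may be only part of what the source reports. "The series", "measured", "known", "first", "only" and "open" are said of these compounds alone.

Three compounds share one core and differ only in the group attached to a carbonyl carbon. Compound 1 `CCN(CC)S(=O)(=O)c1ccc(S(=O)(=O)N2CCC[C@@H](C(=O)N3CCC(F)(F)CC3)C2)cc1` carries a 4,4-difluoropiperidin-1-yl group there, compound 2 `CCN(CC)S(=O)(=O)c1ccc(S(=O)(=O)N2CCC[C@@H](C(=O)N[C@@H]3CCOC3)C2)cc1` an (oxolan-3-yl)amino group, and compound 3 `CCN(CC)S(=O)(=O)c1ccc(S(=O)(=O)N2CCC[C@@H](C(=O)N3CCC(OC)CC3)C2)cc1` a 4-methoxypiperidin-1-yl group. In a functional assay on MIA PaCa-2 cells (Homo sapiens) for inhibition, read by MTT assay, with a stated time of 3 days (on this read-out lower numbers stand for stronger inhibition and higher numbers for weaker inhibition), compound 1 gives no number, only the limit > 10000 nM. In this assay compound 2 likewise stops at the limit > 10000 nM. Compound 3 also reaches no number in this assay, its value being the limit > 10000 nM. Every value shown is the limit of > 10000 nM in this assay, at which 3 of the 3 values shown sit, so the steps a step that the two limits leave unreadable from compound 1 to compound 2, a step that the two limits leave unreadable from compound 1 to compound 3 and a step that the two limits leave unreadable from compound 2 to compound 3 cannot be sized. Compound 4 `CCN(CC)S(=O)(=O)c1ccc(S(=O)(=O)N2CCC[C@@H](C(=O)N[C@H]3CCOC3)C2)cc1` differs from compound 3 by (oxolan-3-yl)amino in place of 4-methoxypiperidin-1-yl on a carbonyl carbon. The closest comparison is a step that the two limits leave unreadable from compound 2 to compound 3, whose size is unreadable. Compound 4 is expected to stay at the limit, the estimated step being a step that the limit leaves unreadable from compound 3 to compound 4. The estimate for compound 4 is 20000 nM, within 8000 nM to 60000 nM.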

Compound 4, half-maximal inhibitory concentration: > 10000 nM
Compound 4: a limit, no number (the forecaster's own chance of this, stated with the estimate: 90%); the middle value lies beyond the limit too.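

Going by these compounds alone, no step from compound 4 to compound 1, compound 2 or compound 3 can be read, as all four compounds stop at a limit: the limit of > 10000 nM in this assay, at which 4 of the 4 values shown sit. The compounds shown leave open whether the group on the carbonyl carbon, or the configuration that separates compound 2 from compound 4, affects inhibition in this assay at all.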